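Phenyl in place of bromo: compound 3 to compound 4

The compounds below may be only part of what the source reports. "The series", "measured", "known", "first", "only" and "open" are said of these compounds alone.

Measured in an ADME assay on L929 cells (Mus musculus) for cytotoxicity, read by resazurin assay, with a stated time of 96 h (on this read-out lower numbers stand for higher toxicity in this test and higher numbers for lower toxicity in this test), so far:
- Compound 1 `NC(=S)N/N=C(/COc1ccc(Br)cc1)c1ccccc1` gives < 27500 nM (a limit).
- Compound 2 `NC(=S)N/N=C(/COc1ccc(Br)cc1)c1ccc(F)cc1` gives < 26200 nM (a limit).
- Compound 3 `NC(=S)N/N=C(/COc1ccc(Br)cc1)c1ccc(Br)cc1` gives 22600 nM (a number).

Among the compounds with values here, compound 3 at 22600 nM holds the only number in the set. The other two entries are limits. The step to compound 4 `NC(=S)N/N=C(/COc1ccc(Br)cc1)c1ccc(-c2ccccc2)cc1` puts phenyl in place of bromo on an aromatic carbon, para to a large group (phenyl in place of bromo on an aromatic carbon) and leaves the rest of the structure unchanged.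

Within the data shown here, three measured steps bear on it, all at this same aromatic carbon. Fluoro in place of hydrogen gives a step that the two limits leave unreadable from compound 1 to compound 2 here. Bromo in place of hydrogen gives a step that the limit leaves unreadable from compound 1 to compound 3 here. Bromo in place of fluoro gives a step that the limit leaves unreadable from compound 2 to compound 3 here. None of them offers a size to carry over, and none involves phenyl.

The expectation therefore rests on compound 3 at 22600 nM alone, with no direction readable and no shift beyond the usual scatter expected in this assay for this change. The expected step is a 1.3-fold lower number from compound 3 to compound 4 (0.10 log units; within the scatter) on this basis. For compound 4 the estimated value is 18000 nM with a range from 7000 nM to 35000 nM as expected bounds.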

Compound 4, half-maximal cytotoxic concentration: 22700 nM
Compound 4: the middle estimate sits 1.3-fold (0.10 log units) below what was measured; measured number inside the range.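

In this assay, within the data shown here, phenyl in place of bromo gives a 1.0-fold higher number from compound 3 to compound 4 (0.00 log units; within the scatter); this is the first step with a readable size, and it lies within the scatter, so at this aromatic carbon, para to a large group, a bromine of 1 heavy atom gives way to a six-membered aromatic ring of 6 heavy atoms with no shift in the read-out. Compound 1 holds a limit, not a number: the limit of < 27500 nM in this assay, at which 1 of the 4 values shown sits.
Compound 2 likewise holds a limit, and the steps from these two compounds to compound 4 cannot be read: the limit of < 26200 nM in this assay, at which 1 of the 4 values shown sits.

Bromo and phenyl both count 0 hydrogen-bond donors and 0 hydrogen-bond acceptors, and the compounds shown leave open how an amine or a carboxylic acid at this aromatic carbon would read in this assay. As far as these compounds go, the rest of the structure stays the same in all four compounds, so what a change elsewhere on the shared core would do to this read-out is equally open.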